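This account rests on a few compounds, and the source may have more. Where it says the series, first, only, none or still open, it means among the compounds named here.

Measured compounds:
compound 1 `Clc1ccc(-c2cc(-c3ccc(Cl)o3)cc(-c3ccsc3)n2)cc1` — 29.8%
compound 2 `Clc1ccc(-c2cc(-c3cccnc3)nc(-c3ccsc3)c2)o1` — 0%

Within the data shown here, in an assay on isolated protein for inhibition of DNA topoisomerase 1 (Homo sapiens), tested at 100 uM (on this read-out lower numbers stand for a weaker effect and higher numbers for a stronger effect at the one concentration tested), compound 2 gives the lower of the two numbers; the only measured step, a number 29.8 percentage points lower from compound 1 to compound 2 (beyond the scatter), brought pyridin-3-yl in and sits beyond the scatter. Compound 3 `Cc1ccc(-c2cc(-c3ccc(Cl)o3)cc(-c3ccsc3)n2)o1` is not yet measured; its change from compound 2 is 5-methylfuran-2-yl in place of pyridin-3-yl on an aromatic carbon. That step bears on it only by reversal: pyridin-3-yl leaves again, and nothing measured tells how 5-methylfuran-2-yl itself behaves. A rise of roughly the size seen in a number 29.8 percentage points lower from compound 1 to compound 2 (beyond the scatter) is therefore expected, so a number 25 percentage points higher from compound 2 to compound 3 (beyond the scatter) is estimated. Compound 3 is expected at 25%, range 0% to 55%.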

Compound 3, a percentage reported as inhibition, at one concentration (the size of the read-out at that concentration, not a potency): 9.1%
Compound 3: the middle estimate sits 15.9 percentage points above what was measured; the range from low to high includes it.
By their numbers in this assay, from the lowest: compounds 2 and 3 (each within the scatter of the next); then compound 1.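

At this position next to the ring nitrogen, the step of a number 20.7 percentage points lower from compound 1 to compound 3 (beyond the scatter) in this assay shows that the drop from 4-chlorophenyl is not confined to pyridin-3-yl. The step of a number 9.1 percentage points higher from compound 2 to compound 3 (within the scatter) does not separate 5-methylfuran-2-yl from pyridin-3-yl, so of the three groups only 4-chlorophenyl stands apart. No evidence bears on the reason for this.

Still open, as far as these compounds go, is whether the chlorine of 4-chlorophenyl matters, which plain phenyl would test. Also open, from the compounds shown here alone, is whether a saturated amine such as morpholin-4-yl at this position would match compound 1 or compound 2.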